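The compounds below may be only part of what the source reports. "The series", "measured", "known", "first", "only" and "open" are said of these compounds alone.

The three measured compounds share one core and differ at the sulfur-bearing chain or at the aromatic substituents. Compound 1 `C=CCSC[C@H](NC(=O)c1cc(OC)c(OC)c(OC)c1)C(=O)OC` gives 49300 nM in an assay on RAW264.7 cells for antagonist activity at Toll-like receptor 2 (Mus musculus), read by Griess assay, with a stated time of 24 h; a lower number here means a stronger inhibitor, a higher number a weaker inhibitor. Compound 2 `C=CCSC[C@H](NC(=O)c1cc(O)c(O)c(O)c1)C(=O)OC` gives 52100 nM in this assay. Compound 3 `C=CCCSC[C@H](NC(=O)c1cc(O)c(O)c(O)c1)C(=O)OC` gives 57800 nM in this assay, which is the highest of the three numbers, though its gaps to compound 2 and to compound 1 are both within the scatter, so no order among the three can be claimed.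

Compound 4 `C=CCCCSC[C@H](NC(=O)c1cc(O)c(O)c(O)c1)C(=O)OC` has not been measured. It differs from compound 3 by allyl in place of vinyl on a saturated chain carbon, two bonds along the chain from a sulfur. Going by the values given here, the one measured step that bears on this change is a 1.1-fold higher number from compound 2 to compound 3 (0.05 log units; within the scatter), a lengthening of the same chain by one carbon that left the number within the scatter. On that basis compound 4 is expected to show a step of a 1.0-fold higher number from compound 3 to compound 4 (0.02 log units; within the scatter) in this assay, that is, none beyond the scatter. Compound 4 is therefore estimated at 60000 nM in this assay, with a likely range from 30000 nM to 120000 nM.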

Compound 4, half-maximal inhibitory concentration: 39200 nM
For compound 4 the middle estimate is 1.5-fold (0.18 log units) above the measured one; the range from low to high includes it.
By their numbers in this assay, from the lowest: compounds 4, 1, 2 and 3 (each within the scatter of the next).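

Lengthening the sulfur-bearing chain once more gives a 1.5-fold lower number from compound 3 to compound 4 (0.17 log units; within the scatter) in this assay and so, like the earlier lengthening, leaves the number within the scatter. Taken over the longer span from the allyl chain to the pent-4-en-1-yl chain, the change gives a 1.3-fold lower number from compound 2 to compound 4 (0.12 log units; within the scatter) in the same read-out, so neither a single extension nor the combined one has produced a step beyond the scatter at this position. No measurement shown offers an explanation for these numbers.

The compounds shown leave open whether a longer chain, or an amine or a carboxylic acid at the end of the chain in place of the terminal double bond, would move the number in this assay beyond the scatter. They also leave open whether a fully saturated chain on the sulfur would do so.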